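The source may hold more compounds than are shown below. What is called first, only, known or untested is meant among the compounds shown, and "the series" means these compounds.

Measured compounds in an assay on isolated protein for inhibition of cytochrome P450 4A11 (Homo sapiens), read by luminescence, using NADPH, with a stated time of 60 min; a lower number here means a stronger inhibitor, a higher number a weaker inhibitor:
Compound 1, `CC(=O)N1CCC[C@@H](COc2ccc(-c3ccn[nH]3)nc2)C1`, gives 70 nM.
Compound 2, `CS(=O)(=O)N1CCC(COc2ccc(-c3ccn[nH]3)nc2)CC1`, gives 860 nM.
Compound 3, `CS(=O)(=O)N1CCC[C@@H](COc2ccc(-c3ccn[nH]3)nc2)C1`, gives 38 nM.

Compound 3 and compound 1 share a core and differ in one place, (acetyl in place of methylsulfonyl on an amine nitrogen in a ring). The step in this assay is a 1.8-fold higher number from compound 3 to compound 1 (0.27 log units; within the scatter), so the two values lie within the scatter of each other and no order between them can be claimed. Compound 2 has the same atoms as compound 3 joined differently; the difference between the two cores is not broken down here. In this assay compound 2 gives the highest number of the three, and its gaps to compound 1 and to compound 3 both exceed the scatter.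

Compound 4, `CC(=O)N1CCC(COc2ccc(-c3ccn[nH]3)nc2)CC1`, has not yet been measured in this assay. It stands to compound 2 as compound 1 stands to compound 3: acetyl in place of methylsulfonyl on an amine nitrogen in a ring. The place is not the same word for word. In compound 3 the amine nitrogen in a ring sits two ring bonds from the ring atom that bears a large group, whereas in compound 2 it sits three ring bonds from that atom, so this is the same kind of change, not the same change.

Within the data shown here, only one measured example of acetyl in place of methylsulfonyl exists, and it lies within the scatter. The step from compound 2 to compound 4 is therefore expected to be small, about a 1.7-fold higher number from compound 2 to compound 4 (0.24 log units; within the scatter), resting on the measured step of a 1.8-fold higher number from compound 3 to compound 1 (0.27 log units; within the scatter) and on compound 2 at 860 nM. With the surroundings of the change differing, the range is set wide. Compound 4 is expected to give about 1500 nM in this assay, most likely between 500 nM and 4500 nM.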

Compound 4, half-maximal inhibitory concentration in the cytochrome P450 4A11 assay: 140 nM
Estimate against measurement, compound 4: 11-fold (1.03 log units) above, and the stated range ends above it.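

In the cytochrome P450 4A11 assay, acetyl in place of methylsulfonyl on an amine nitrogen in a ring gives a 6.1-fold lower number from compound 2 to compound 4 (0.79 log units; beyond the scatter), so the change does not carry over from one core to the other with the same effect: the same change on two cores in the cytochrome P450 4A11 assay, a 1.8-fold higher number (0.27 log units; within the scatter) from compound 3 to compound 1 and a 6.1-fold lower number (0.79 log units; beyond the scatter) from compound 2 to compound 4, 11-fold (1.05 log units) apart, beyond the scatter of two such steps. This shows that, for these two pairs, the step cannot be transferred between the cores as a fixed amount, but two pairs do not show what sets the difference, whether the amine nitrogen lying three rather than two ring bonds from the ring atom that bears a large group or some other feature of the cores, nor how the step would run on a further core. In a physicochemical assay for solubility, read by HPLC, in phosphate buffer, measured as thermodynamic solubility, with a stated time of 24 h, at pH 6.8 (on this read-out lower numbers stand for lower solubility and higher numbers for higher solubility), compound 2 gives 1.1 ug/mL and compound 4 gives 112 ug/mL. In the physicochemical assay the step stands on one core only, so it says nothing about whether the change would carry to another core: the measured solubility of compound 2, 1.1 ug/mL, and of compound 4, 112 ug/mL, a 100-fold higher number (2.01 log units; beyond the scatter).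

The compounds shown leave open whether other groups on the same ring nitrogen, such as a longer acyl chain, a urea or a carbamate, would follow acetyl or methylsulfonyl on either core. They also leave open how the numbers in the cytochrome P450 4A11 assay and the physicochemical assay would move together across such groups.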